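Chloro addition to the 4-chlorophenyl ring of compound 3

A few compounds are considered here, and "the series" means these few. Any claim that something is new, unique, unknown or untested is made for them only; others in the source may bear on it.

Measured in an ADME assay on L02 cells (Homo sapiens) for cytotoxicity, read by MTT assay, with a stated time of 24 h; on this read-out lower numbers stand for stronger inhibition and higher numbers for weaker inhibition:
- compound 1 `COc1cc(/C=C2\CN(C)C/C(=C\c3ccccc3F)C2=O)cc(OC)c1`: 11900 nM
- compound 2 `COc1cc(/C=C2\CN(C)C/C(=C\c3ccccc3F)C2=O)cc(OC)c1OC`: 12100 nM
- compound 3 `COc1cc(/C=C2\CN(C)C/C(=C\c3ccc(Cl)cc3)C2=O)cc(OC)c1`: 18900 nM

At 18900 nM, compound 3 lies within the scatter of both other compounds, so the three values form one narrow band in this assay.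

Compound 4 `COc1cc(/C=C2\CN(C)C/C(=C\c3ccc(Cl)cc3Cl)C2=O)cc(OC)c1` is the next case. The difference is chloro in place of hydrogen on an aromatic carbon, which is chloro in place of hydrogen on an aromatic carbon, or 4-chlorophenyl to 2,4-dichlorophenyl.

Within the data shown here, no measured step is this same change, so the support is indirect. The nearest evidence is a 1.6-fold higher number from compound 1 to compound 3 (0.20 log units; within the scatter), with 4-chlorophenyl in place of 2-fluorophenyl on the ring that changes here. A second step, a 1.0-fold higher number from compound 1 to compound 2 (0.01 log units; within the scatter), is methoxy in place of hydrogen on an aromatic carbon of the other ring. Neither step leaves the scatter, and the data show no direction for adding a substituent.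

No step beyond the scatter is therefore expected in this assay, in either direction. The expected step is a 1.3-fold lower number from compound 3 to compound 4 (0.10 log units; within the scatter), which would keep the value within the same band. For compound 4 the estimated value is 15000 nM, with an expected range of 8000 nM to 28000 nM.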

Compound 4, half-maximal inhibitory concentration: 18800 nM
Compound 4: middle estimate off by 1.3-fold (0.10 log units), on the low side, within the range that was stated.
By their numbers in this assay, from the lowest: compounds 1, 2, 4 and 3 (each within the scatter of the next).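

In this assay, the aromatic carbon ortho to a large group and meta to a chloro group accepts a chloro in place of hydrogen with a 1.0-fold lower number from compound 3 to compound 4 (0.00 log units; within the scatter) and no departure from the band. Among these compounds, no earlier step added a second halogen to a ring already carrying one, and the comparison of the 2,4-dichlorophenyl group with the 2-fluorophenyl group, at a 1.6-fold higher number from compound 1 to compound 4 (0.20 log units; within the scatter), also stays within the scatter. The 2-fluorophenyl, 4-chlorophenyl and 2,4-dichlorophenyl rings therefore cannot be told apart in this read-out, and nothing in the available data offers an account of this flat result.

Every substituent shown on this ring is a halogen, so it remains open whether an amine, a hydroxyl or a carboxylic acid there would move the number beyond the scatter. The methyl on the ring nitrogen of the shared core is also constant across all four compounds, which leaves open what a longer chain or an acyl group at that nitrogen would do in this assay.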